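This account rests on a few compounds, and the source may have more. Where it says the series, first, only, none or still open, it means among the compounds named here.

In a functional assay on CHO cells for agonist activity at Melanocortin receptor 4 (Homo sapiens), read by a luciferase reporter, with a stated time of 4 h (a higher number here means that more compound is needed for the effect, a lower number that less compound is needed), compound 1, with the structure `COc1ccc(N(C(=O)CN2C=CN(c3ccccc3)C(=O)[C@@H](Cc3n[nH]c4ccccc34)C2=O)C(C)C)cc1`, gives 31600 nM; > 30000 nM (2 entries). Part of that record for compound 1 is a limit of the assay rather than a number, so its measured potency is only loosely pinned down. Compound 2, with the structure `CC(C)N(C(=O)CN1C=CN(c2ccccc2)C(=O)[C@H](Cc2n[nH]c3ccccc23)C1=O)c1ccccc1`, gives 1070 nM in this assay, and that is the only number shown for it, with one further entry that carries no single number. Since the two compounds differ in more than one place, their values are simply two points side by side and no single change can be read from them.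

Compound 3, with the structure `COc1ccc(N(C(=O)CN2C=CN(c3ccccc3)C(=O)[C@H](Cc3n[nH]c4ccccc34)C2=O)C(C)C)cc1`, has not yet been measured. It differs from compound 2 by methoxy in place of hydrogen on an aromatic carbon of a six-membered aromatic ring of carbon only. Among the compounds with values here, no measured pair with this change stands in the data, so the size of its effect is unknown; a step of this kind is expected to stay within or only just beyond the usual scatter. Compound 3 is therefore estimated at 1500 nM, with a likely range from 500 nM to 5000 nM, which means an expected step of a 1.4-fold higher number from compound 2 to compound 3 (0.15 log units; within the scatter).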

Compound 3, half-maximal effective concentration: 339 nM
Estimate against measurement, compound 3: 4.4-fold (0.65 log units) above; the measured number lies below the stated range.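

In this assay, within the data shown here, putting methoxy in place of hydrogen on an aromatic carbon, para to a large group, turns phenyl into 4-methoxyphenyl and gives a 3.2-fold lower number from compound 2 to compound 3 (0.50 log units; beyond the scatter) in the first measured pair with this change, so at this position less compound is needed for the effect once the methoxy group is present. Compound 1 carries the same 4-methoxyphenyl group, yet its record stays in the high range and part of it is a limit of the assay, not a number: the several entries of compound 1 in this assay, 31600 nM; > 30000 nM (2 entries). The methoxy group therefore does not bring the lower number on its own, and the configuration matters too, since only that one feature separates the much weaker record of compound 1 from the result for compound 3: the fact that compounds 1 and 3 differ only in the configuration as drawn.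

Going by these compounds, whether a hydroxyl group, a chlorine atom or the longer ethoxy chain on the same aromatic carbon would move the number in the same way stays open, and so does the effect of methoxy on another carbon of that ring. A single pair also cannot show whether this step would carry over to other compounds built on the shared core.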